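Furan Replaces Nitrophenyl on the Amide of a Naphthyl Carbinol

A few compounds are considered here, and "the series" means these few. Any claim that something is new, unique, unknown or untested is made for them only; others in the source may bear on it.

Measured compounds:
compound 1 `CCC(=O)Nc1c(C(O)(C(F)(F)F)C(F)(F)F)ccc2ccccc12` — 15 nM
compound 2 `O=C(CCc1ccccc1)Nc1c(C(O)(C(F)(F)F)C(F)(F)F)ccc2ccccc12` — 1750 nM
compound 3 `O=C(Nc1c(C(O)(C(F)(F)F)C(F)(F)F)ccc2ccccc12)c1cccc([N+](=O)[O-])c1` — 117 nM

In an assay on LtK cells with ATP-sensitive inward rectifier potassium channel 11 (Homo sapiens) as the target (on this read-out lower numbers stand for an effect already at smaller amounts and higher numbers for an effect only at larger amounts of compound), compound 3 gives 117 nM, the second highest of the three numbers. Its nearest neighbour is compound 1, reached by a 7.8-fold higher number from compound 1 to compound 3 (0.89 log units; beyond the scatter); compound 2 lies further off, and a 15-fold lower number from compound 2 to compound 3 (1.17 log units; beyond the scatter) separates the two. Compound 4 `O=C(Nc1c(C(O)(C(F)(F)F)C(F)(F)F)ccc2ccccc12)c1ccco1` is derived from compound 3 by the change (furan-2-yl in place of 3-nitrophenyl on a carbonyl carbon).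

Going by the values given here, two measured steps bear on this change. Placing 3-nitrophenyl in place of ethyl on the carbonyl carbon raised the number modestly, as a 7.8-fold higher number from compound 1 to compound 3 (0.89 log units; beyond the scatter) shows, whereas the same aromatic group in place of phenethyl lowered it strongly, as a 15-fold lower number from compound 2 to compound 3 (1.17 log units; beyond the scatter) shows. Both ends of the new step carry an aromatic ring on the carbonyl carbon, so the shift is expected to be smaller than either of those steps. Compound 4 is therefore estimated at 60 nM in this assay, with a range of 20 nM to 200 nM. That estimate means a step of a 2.0-fold lower number from compound 3 to compound 4 (0.29 log units; within the scatter), a modest lowering that may not exceed the scatter.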

Compound 4, half-maximal effective concentration: 9 nM
Compound 4: the middle estimate sits 6.7-fold (0.82 log units) above what was measured; the whole stated range lies above it.
By their numbers in this assay, from the lowest: compounds 4 and 1 (each within the scatter of the next); then compound 3; then compound 2.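

In this assay, the step of a 13-fold lower number from compound 3 to compound 4 (1.11 log units; beyond the scatter) shows that the kind of aromatic ring on the carbonyl carbon matters, not merely the presence of one: two aromatic groups at this place can lie far apart. The step of a 1.7-fold lower number from compound 1 to compound 4 (0.22 log units; within the scatter) shows that furan-2-yl and ethyl cannot be told apart at this place, while the step of a 190-fold lower number from compound 2 to compound 4 (2.29 log units; beyond the scatter) sets furan-2-yl far from phenethyl. Nothing given here explains these differences.

The compounds shown leave open whether the furan-2-yl group itself accounts for the step or whether the nitro group on the 3-nitrophenyl ring does. A plain phenyl, a thiophen-2-yl or a cyclopropyl group on the carbonyl carbon would help separate these readings.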